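The source may report more compounds than this note shows. Statements on the series, on what has been measured and on what is new or still open speak of the compounds shown alone.

Of the compounds shown here, three built on one shared core have been tested in a functional assay on A549 cells (Homo sapiens) for inhibition, read by MTT assay, with a stated time of 72 h, tested at 20 uM; on this read-out higher numbers stand for more inhibition at the one concentration tested (going by the name of the read-out) and lower numbers for less inhibition. Compound 1 `CN(c1ccc(Oc2ncnc3ccsc23)cc1)c1nccc(N2CCCC2)n1` gives 63.9%. Compound 2 `CN(c1ccc(Oc2ncnc3ccsc23)cc1)c1nccc(N2CCc3ccccc3C2)n1` gives 69.9%, and compound 3 `CN(c1ccc(Oc2ncnc3ccsc23)cc1)c1nccc(N2CCCCC2)n1` gives 65.7%. Compound 2 holds the highest of these three numbers, but the gaps are small: the step of a number 6 percentage points higher from compound 1 to compound 2 (within the scatter) and the step of a number 4.2 percentage points lower from compound 2 to compound 3 (within the scatter) both stay within the scatter, as does a number 1.8 percentage points higher from compound 1 to compound 3 (within the scatter). Exchanging pyrrolidin-1-yl for piperidin-1-yl or for 1,2,3,4-tetrahydroisoquinolin-2-yl on the aromatic carbon thus leaves the read-out essentially where it was.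

Compound 4 `c1ccc2c(c1)CCN(c1ccnc(Nc3ccc(Oc4ncnc5ccsc45)cc3)n1)C2` has not yet been measured. It differs from compound 2 in a single place: hydrogen in place of methyl on a nitrogen on an aromatic ring. Going by the values given here, none of the measured steps touches this nitrogen, so there is no direct precedent for the change. What the three measured compounds do show is a read-out that has stayed in a narrow band through every change tried, and the change to compound 4 is a modest one. The step of a number 3.9 percentage points lower from compound 2 to compound 4 (within the scatter) expected from this is none beyond the scatter. Compound 4 is therefore estimated to give 66% in this assay, with a range from 52% to 80%.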

Compound 4, a percentage reported as inhibition, at one concentration (the size of the read-out at that concentration, not a potency): 54.9%
For compound 4 the middle estimate is 11.1 percentage points above the measured one; the measured number falls inside the stated range.
By their numbers in this assay, from the lowest: compounds 4, 1, 3 and 2 (each within the scatter of the next, the first and the last beyond it).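

Among the compounds shown, this nitrogen on an aromatic ring is the first place where a single change moves the number in this assay beyond the scatter: hydrogen in place of methyl gives a clear step (a number 15 percentage points lower from compound 2 to compound 4 (beyond the scatter)). The change is small on paper, since the only heavy atom that leaves is the one carbon of the methyl, yet the step is larger than any of the exchanges among pyrrolidin-1-yl, piperidin-1-yl and 1,2,3,4-tetrahydroisoquinolin-2-yl, which all stayed within the scatter. Nothing available here explains why this loss of inhibition at the one concentration tested occurs.

The compounds shown leave open whether hydrogen in place of methyl has a similar effect when pyrrolidin-1-yl or piperidin-1-yl sits on the aromatic carbon, since this step is seen only with 1,2,3,4-tetrahydroisoquinolin-2-yl. They also leave open how an ethyl, a longer alkyl chain or an acetyl on this nitrogen would compare with the methyl of compound 2.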